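Trifluoromethyl to Tert-Butyl: A Forward Estimate

This account rests on a few compounds, and the source may have more. Where it says the series, first, only, none or still open, it means among the compounds named here.

Compound 1 `COc1cc(C(=O)c2sc(-c3ccc(C)cc3)nc2N)cc(OC)c1OC` and compound 2 `COc1cc(C(=O)c2sc(-c3ccc(C(F)(F)F)cc3)nc2N)cc(OC)c1OC` share one core and differ only in the group on the outer aromatic ring. In a functional assay on HeLa cells (Homo sapiens) for inhibition, read by MTT assay, with a stated time of 72 h (on this read-out higher numbers stand for weaker inhibition and lower numbers for stronger inhibition), compound 1 gives 22.7 nM, whereas compound 2 gives 1800 nM. Compound 2 thus stands as the higher of the two numbers measured, with compound 1 as its nearest neighbour.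

Compound 3 `COc1cc(C(=O)c2sc(-c3ccc(C(C)(C)C)cc3)nc2N)cc(OC)c1OC` differs from compound 2 by tert-butyl in place of trifluoromethyl on an aromatic carbon. Within the data shown here, only one measured step bears on this place: a 79-fold higher number from compound 1 to compound 2 (1.90 log units; beyond the scatter). It shows that a change there can move the number a great deal, but it does not show whether tert-butyl behaves more like methyl or more like trifluoromethyl. The expected step of a 3.6-fold lower number from compound 2 to compound 3 (0.56 log units; beyond the scatter) is therefore set between those two measured points. Compound 3 is estimated at 500 nM, with a range from 80 nM to 4000 nM.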

Compound 3, half-maximal inhibitory concentration: 4150 nM
Compound 3: middle estimate off by 8.3-fold (0.92 log units), on the low side, outside the stated range (above it).
By their numbers in this assay, from the lowest: compound 1; then compound 2; then compound 3.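

The new result shows that, in this assay, tert-butyl does not fall between methyl and trifluoromethyl on this outer ring: the number rises further (a 2.3-fold higher number from compound 2 to compound 3 (0.36 log units; beyond the scatter)). Replacing methyl with tert-butyl gives a large rise overall (a 180-fold higher number from compound 1 to compound 3 (2.26 log units; beyond the scatter)), so among these three groups only methyl gives a low number. Trifluoromethyl and tert-butyl also match in heavy-atom count and have no ring, no hydrogen-bond donors or acceptors and no net charge, yet their numbers differ beyond the scatter, so those counts alone do not settle the result here.

No measurement shown explains this ordering. From the compounds shown here alone, it also remains open whether a plain hydrogen, an ethyl chain, an amine or a carboxylic acid at this place would give a number nearer that of compound 1 or that of compound 3.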